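The source may report more compounds than this note shows. Statements on the series, on what has been measured and on what is new or still open speak of the compounds shown alone.

Compound 1 `COC/C1=C/C[C@](C)(CCC=C(C)C)/C=C/[C@@H](OC(=O)C=C(C)C)[C@](C)(O)/C=C/C1=O` was tested in a functional assay on HL-60 cells (Homo sapiens) for antiproliferative activity, read by MTT assay, with a stated time of 48 h; a higher number here means a weaker inhibitor, a lower number a stronger inhibitor. In this assay compound 1 gives 3070 nM, and this is the only outright number among the two results shown. Compound 2 `CC(C)=CCC[C@]1(C)/C=C/[C@@H](OC(=O)C=C(C)C)[C@](C)(O)/C=C/[C@H](O)/C(CO)=C\C1` gives > 40000 nM in this assay, which is a limit of the assay rather than a measured number (the limit of > 40000 nM in this assay, at which 1 of the 2 values shown sits).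

Compound 3 `CC(C)=CCC[C@]1(C)/C=C/[C@@H](OC(=O)C=C(C)C)[C@](C)(O)/C=C/C(=O)/C(C(=O)N(C)C)=C\C1` has not yet been measured. It differs from compound 1 in a single place: dimethylcarbamoyl in place of methoxymethyl on a double-bonded ring carbon. Among the compounds with values here, the change sits on a double-bonded ring carbon of the non-aromatic ring of carbon only that forms the shared core; everything else in compound 1 is kept.

Within the data shown here, no pair of measured compounds that differ in one place is available here, so the size of this step cannot be read from a comparable change. The expected step from compound 1 to compound 3 in this assay is a 1.5-fold higher number from compound 1 to compound 3 (0.17 log units; within the scatter), a shift that may well stay within the usual scatter. For compound 3 the estimated result in this assay is 4500 nM, expected to lie between 1000 nM and 20000 nM.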

Compound 3, half-maximal inhibitory concentration: 3340 nM
Beside the measured number, compound 3's estimate is 1.3-fold (0.13 log units) above it; the range from low to high includes it.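

In this assay, replacing methoxymethyl with dimethylcarbamoyl on the double-bonded ring carbon gives a 1.1-fold higher number from compound 1 to compound 3 (0.04 log units; within the scatter), so compound 1 and compound 3 cannot be told apart by this measurement. Within the data shown here, this is the first comparison at this position, and it shows that the position can carry dimethylcarbamoyl, with 5 heavy atoms and a double bond outside aromatic rings, in place of methoxymethyl, with 3 heavy atoms, without a change in the read-out that exceeds the usual scatter of repeated measurements. Both groups have 1 hydrogen-bond acceptor and 0 hydrogen-bond donors, but nothing measured here explains why the two compounds match.

As far as these compounds go, with only this one replacement to read, it remains open whether a carboxylic acid, an amine or a longer chain on the same ring carbon would give a similar result. Compound 2 gives > 40000 nM, which is a limit of the assay and not a number, and since it differs from compound 1 in more than one place, it cannot show what this position alone contributes.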